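The source may hold more compounds than are shown below. What is called first, only, known or untested is meant among the compounds shown, and "the series" means these compounds.

Compound 1, `CCOC(=O)c1cnc(SC)nc1NN1C(=O)C=C(C)C1=O`: 200 nM
Compound 2, `CCOC(=O)c1cnc(-c2ccc(Cl)cc2)nc1NN1C(=O)C=C(C)C1=O`: 300 nM
Compound 3, `CCOC(=O)c1cnc(-c2cc3ccccc3s2)nc1NN1C(=O)C=C(C)C1=O`: 4000 nM

These three compounds share one core and differ only in the group on an aromatic carbon between two ring nitrogen atoms, and all were tested in a functional assay on Jurkat cells for inhibition of nuclear factor NF-kappa-B complex (Homo sapiens); on this read-out lower numbers stand for stronger inhibition and higher numbers for weaker inhibition. Compound 1 stands at the low end of the three numbers; compound 2 sits close by, a 1.5-fold higher number from compound 1 to compound 2 (0.18 log units; within the scatter), and compound 3 far off, a 20-fold higher number from compound 1 to compound 3 (1.30 log units; beyond the scatter). Compound 3 also stands apart from compound 2, a 13-fold higher number from compound 2 to compound 3 (1.12 log units; beyond the scatter).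

Compound 4, `CCOC(=O)c1cnc(Cc2ccccc2)nc1NN1C(=O)C=C(C)C1=O`, has not yet been measured. Its difference from compound 1 is benzyl in place of methylsulfanyl on an aromatic carbon. Within the data shown here, both measured steps from compound 1 bear on this: the one to compound 2 stayed within the scatter, the one to compound 3 was large. Benzyl carries a six-membered aromatic ring of carbon only, as 4-chlorophenyl does, and lacks the second ring of 1-benzothiophen-2-yl. A modest step toward a higher number in this assay is therefore expected, a 2.5-fold higher number from compound 1 to compound 4 (0.40 log units; beyond the scatter). For compound 4 the estimate is 500 nM, with a range from 150 nM to 2500 nM.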

Compound 4, half-maximal inhibitory concentration: 7000 nM
Compound 4: the middle estimate sits 14-fold (1.15 log units) below what was measured; measured number outside the range, above it.
By their numbers in this assay, from the lowest: compounds 1 and 2 (each within the scatter of the next); then compounds 3 and 4 (each within the scatter of the next).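

Benzyl and 4-chlorophenyl each carry one six-membered aromatic ring of carbon only, yet they do not behave alike at this position: in this assay the swap between them gives a 23-fold higher number from compound 2 to compound 4 (1.37 log units; beyond the scatter) and places benzyl far from 4-chlorophenyl. Replacing methylsulfanyl with benzyl likewise gives a 35-fold higher number from compound 1 to compound 4 (1.54 log units; beyond the scatter) as a large step, so having that kind of ring does not by itself keep the number low here. The second ring of 1-benzothiophen-2-yl is also not required for a high number, since the change to benzyl gives a 1.8-fold higher number from compound 3 to compound 4 (0.24 log units; within the scatter) and leaves the two compounds together, and no supporting data explain any of these differences.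

Still open, on these data alone, is whether plain phenyl would fall with 4-chlorophenyl or with benzyl. Also open, as far as these compounds go, is whether a small group at this place, such as an amine or a methoxy group, would stay near compound 1 in this assay or move away from it.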